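Benzylamino analogue of the cell-growth series

A few compounds are considered here, and "the series" means these few. Any claim that something is new, unique, unknown or untested is made for them only; others in the source may bear on it.

Working notes on two measured compounds and one awaiting a number. Compound 1 `COc1ccc(NC2=CC(=O)c3c(nc4n3[C@H]3OC[C@@H](O)[C@H]3OC4)C2=O)cc1` is the anchor: in a functional assay on ECa-109 cells for inhibition, with ECa-109 cell line (Homo sapiens) as the target, read by sulforhodamine B assay (on this read-out lower numbers stand for stronger inhibition and higher numbers for weaker inhibition), compound 1 gives 3410 nM, the lowest of the two numbers in hand. Compound 2 `CCOc1ccccc1NC1=CC(=O)c2nc3n(c2C1=O)[C@H]1OC[C@@H](O)[C@H]1OC3` gives 4630 nM in this assay, and the gap between the two compounds is within the usual scatter, so the numbers do not separate them.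

Compound 3 `O=C1C(NCc2ccccc2)=CC(=O)c2c1nc1n2[C@H]2OC[C@@H](O)[C@H]2OC1` has not yet been measured in this assay. Relative to compound 1 it carries the change (benzyl in place of 4-methoxyphenyl on an amine nitrogen). Among the measured compounds shown here, no pair of measured compounds shows this change, so there is no step to lean on. With both measured compounds sitting close together, the expectation for compound 3 is a step in the direction of weaker inhibition, possibly no larger than the scatter, written as a 1.8-fold higher number from compound 1 to compound 3 (0.25 log units; within the scatter). Compound 3 is therefore estimated at 6000 nM in this assay, within a range from 2000 nM to 18000 nM.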

Compound 3, half-maximal inhibitory concentration: > 8000 nM
Compound 3: a limit, no number; the forecaster's own chance of this, stated with the estimate: 5%; at least 1.3-fold (0.12 log units) between middle value and limit.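

In this assay compound 3 stands at > 8000 nM as a limit of the assay and not a number. Benzyl in place of 4-methoxyphenyl on an amine nitrogen gives an at least 2.3-fold higher number from compound 1 to compound 3 (0.37 log units; beyond the scatter) and so is the first step in the series that lies beyond the scatter. From the compounds shown here alone, the group on this nitrogen can therefore move the read-out, which compound 1 and compound 2 could not show, though the full size of the step stays unknown.

This single change swaps the aryl group on the nitrogen for benzyl and also removes the methoxy group, so the compounds shown cannot say which part of it carries the step. A plain phenyl, a 4-methoxybenzyl or a longer chain such as phenethyl on this nitrogen would help separate the two.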